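The source may report more compounds than this note shows. Statements on the series, on what has been measured and on what is new or still open speak of the compounds shown alone.

Of the compounds shown here, two built on a shared core have been measured in a functional assay on Jurkat cells (Homo sapiens) for inhibition, read by CCK-8 assay, with a stated time of 48 h; a higher number here means a weaker inhibitor of growth, a lower number a stronger inhibitor of growth. Compound 1 `Cc1ccccc1Nc1nc(Nc2ccc(N3CCN(C)CC3)cn2)ncc1Cl` gives 8080 nM, while compound 2 `COc1cccc(CNc2nc(Nc3ccc(N4CCN(C)CC4)cn3)ncc2Cl)c1` gives 73400 nM, the higher of the two numbers. Among the measured compounds shown here, the only measured step is a 9.1-fold higher number from compound 1 to compound 2 (0.96 log units; beyond the scatter), with 3-methoxybenzyl in place of 2-methylphenyl on a nitrogen on an aromatic ring.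

Compound 3 `CC(C)c1cccc(Nc2nc(Nc3ccc(N4CCN(C)CC4)cn3)ncc2Cl)c1` has not yet been measured. It differs from compound 2 at that nitrogen, with 3-isopropylphenyl in place of 3-methoxybenzyl on a nitrogen on an aromatic ring. The same difference can be read as (3-methoxybenzyl)amino to (3-isopropylphenyl)amino.

For the measured compounds named here, the one measured step bears on this change, but only partly. Like compound 1, compound 3 carries a substituted phenyl on the nitrogen rather than a benzyl group, so the change broadly runs against a 9.1-fold higher number from compound 1 to compound 2 (0.96 log units; beyond the scatter). Going by the values given here, no measured compound carries 3-isopropylphenyl, so the size remains uncertain. A fall of similar size is expected in this assay, and the estimated step is a 10-fold lower number from compound 2 to compound 3 (1.02 log units; beyond the scatter). For compound 3 the expected value is 7000 nM, with an estimated range from 1800 nM to 27000 nM.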

Compound 3, concentration for 50% growth inhibition: 12300 nM
The estimate for compound 3 lay 1.8-fold (0.24 log units) below the measured number, within the range that was stated.
By their numbers in this assay, from the lowest: compounds 1 and 3 (each within the scatter of the next); then compound 2.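

In this assay, among the compounds shown here, 3-isopropylphenyl in place of 3-methoxybenzyl on the nitrogen gives a 6.0-fold lower number from compound 2 to compound 3 (0.78 log units; beyond the scatter), so a second phenyl group attached directly to that nitrogen, carrying a different substituent from the one in compound 1, also stands apart from the benzyl compound. Between the two phenyl compounds there is a 1.5-fold higher number from compound 1 to compound 3 (0.18 log units; within the scatter), so 2-methylphenyl and 3-isopropylphenyl cannot be told apart at this position in this assay, and among the three compounds only compound 2, the one benzyl compound, stands apart from the others. No data on hand explain why the benzyl compound differs from the two phenyl compounds.

The change from compound 2 to compound 3 swaps the benzyl group for a phenyl group and the methoxy group for an isopropyl group in a single step, so the compounds shown leave open how much of the step belongs to each part. A 3-methoxyphenyl or a 3-isopropylbenzyl group on the same nitrogen would separate the two, and an unsubstituted phenyl group would show what the substituents on the ring contribute at all.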